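Urea series: cinnamamide change from compound 3 to compound 4

A few compounds are considered here, and "the series" means these few. Any claim that something is new, unique, unknown or untested is made for them only; others in the source may bear on it.

Compound 3 `CNC(=O)/C=C(\C)c1ccc(NC(=O)Nc2ccc(Cl)c(C(F)(F)F)c2)cc1` stands at a limit: in a functional assay on MX1 cells (Homo sapiens) for inhibition, read by MTT assay, with a stated time of 120 h (on this read-out higher numbers stand for weaker inhibition and lower numbers for stronger inhibition), compound 3 gives > 50000 nM, which is a limit of the assay and not a number. Compound 2 `CNC(=O)/C(C)=C/c1ccc(NC(=O)Nc2ccc(Cl)c(C(F)(F)F)c2)cc1` likewise reaches only a limit, compound 2 giving > 50000 nM in this assay. Among the measured compounds shown here, compound 1 `CC(NC(=O)/C=C/Oc1ccc(NC(=O)Nc2cc(C(F)(F)F)ccc2Cl)cc1)c1ccccc1` is the one measured number; in this assay compound 1 gives 16100 nM. The step that the two limits leave unreadable from compound 2 to compound 3 cannot be read, since both of its ends rest on (the limit of > 50000 nM in this assay, at which 2 of the 3 values shown sit). Compound 4 `O=C(/C=C/c1ccc(NC(=O)Nc2ccc(Cl)c(C(F)(F)F)c2)cc1)NC1CCC1` carries the change (2-(cyclobutylcarbamoyl)ethenyl in place of 1-methyl-2-(methylcarbamoyl)ethenyl on an aromatic carbon). No measured step bears on this change: the single step shown is unreadable, and compound 1 differs from compound 3 in more than one place. The expectation for compound 4 is therefore weak inhibition close to the limit, with the step of an at least 1.4-fold lower number from compound 3 to compound 4 (0.15 log units; that floor lies within the scatter) expected. Compound 4 is estimated at 35000 nM, in the range 8000 nM to 100000 nM.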

Compound 4, half-maximal inhibitory concentration: 4530 nM
Beside the measured number, compound 4's estimate is 7.7-fold (0.89 log units) above it; measured number outside the range, below it.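

In this assay, among the compounds shown here, compound 4 is the only one of the compounds changed at this aromatic carbon that gives a number, so the position can take a group that moves the read-out off the limit. The change brings an at least 11-fold lower number from compound 3 to compound 4 (1.04 log units; beyond the scatter) and an at least 11-fold lower number from compound 2 to compound 4 (1.04 log units; beyond the scatter). Both sizes are floors, and the step between compound 2 and compound 3 cannot be read, because both compounds rest on a limit: the limit of > 50000 nM in this assay, at which 2 of the 4 values shown sit.

The change joins the cyclobutyl group with the loss of the methyl on the ethenyl chain, and the compounds shown do not separate the two. As far as these compounds go, whether the number would hold with methylcarbamoyl on the unbranched ethenyl, or with a cyclopropyl group or longer alkyl chain on the amide nitrogen, stays open.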